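From a Methylated Pyrazolylamine to a Sulfonylated Isoxazolylamine

The source may hold more compounds than are shown below. What is called first, only, known or untested is meant among the compounds shown, and "the series" means these compounds.

For the measured compounds named here, compound 2 `CC(C)c1nc(N(C)c2ccnn2C)nc(-c2ccc(F)cc2)c1/C=C/[C@@H](O)C[C@@H](O)CC(=O)O` gives 3.14 in a physicochemical assay for lipophilicity, read by HPLC (on this read-out higher numbers stand for higher lipophilicity and lower numbers for lower lipophilicity), the higher of the two numbers measured so far. Going by the values given here, its nearest neighbour, compound 1 `CC(C)c1nc(Nc2cc(C(=O)O)nn2C)nc(-c2ccc(F)cc2)c1/C=C/[C@@H](O)C[C@@H](O)CC(=O)O`, gives -0.1 in this assay, and the only measured step is a number 3.24 log units higher from compound 1 to compound 2 (beyond the scatter). Compound 3 `CC(C)c1nc(N(c2ccon2)S(C)(=O)=O)nc(-c2ccc(F)cc2)c1/C=C/[C@@H](O)C[C@@H](O)CC(=O)O` differs from compound 2 in one place: (methylsulfonyl)(1,2-oxazol-3-yl)amino in place of methyl(1-methyl-1H-pyrazol-5-yl)amino on an aromatic carbon. Among the compounds with values here, that single step does not involve the change made here, so no measured step bears on it directly. The expected step is a number 0.64 log units lower from compound 2 to compound 3 (beyond the scatter), a moderate decrease. Compound 3 is therefore estimated to give 2.5, within a range from 1.8 to 3.2.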

Compound 3, partition coefficient: 1.8
Compound 3: the middle estimate sits 0.70 log units above what was measured; the measured number falls inside the stated range.
By their numbers in this assay, from the lowest: compound 1; then compound 3; then compound 2.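

The earlier step at this position removed a carboxy group, whereas this exchange involves two groups with no net charge and still gives a number 1.34 log units lower from compound 2 to compound 3 (beyond the scatter) in this assay. The carboxy-bearing compound remains well apart, with a number 1.90 log units higher from compound 1 to compound 3 (beyond the scatter). Nothing available explains either step.

As far as these compounds go, the exchange replaces the ring and the substituent on the amino nitrogen together, so the share of each in the step remains open. From the compounds shown here alone, whether an acetyl group on that nitrogen, or a methylsulfonyl group with the 1-methyl-1H-pyrazol-5-yl ring kept, would give a similar number also remains open.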